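Swapping Vinyl for Methyl: Expected Binding of Compound 4

The source may hold more compounds than are shown below. What is called first, only, known or untested is meant among the compounds shown, and "the series" means these compounds.

Three compounds have been measured in an assay on HEK293 cells for binding affinity to 5-hydroxytryptamine receptor 7 (Homo sapiens), read by radioligand binding, tested at 1 uM; a lower number here means less inhibition, a higher number more inhibition at the concentration tested (going by the name of the read-out):
Compound 1 `CN1CCCN(CCn2ccc3ccc(O)cc32)CC1` gives 28%.
Compound 2 `CN1CCCN(CCn2ccc3ccc(C(N)=O)cc32)CC1` gives 33%.
Compound 3 `C=Cc1ccc2ccn(CCN3CCCN(C)CC3)c2c1` gives 79%.

Compound 3 stands highest of the three, with compound 2 nearest and compound 1 furthest. The steps up to it, a number 51 percentage points higher from compound 1 to compound 3 (beyond the scatter) and a number 46 percentage points higher from compound 2 to compound 3 (beyond the scatter), are both beyond the scatter, whereas a number 5 percentage points higher from compound 1 to compound 2 (within the scatter) is within it.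

Compound 4 `Cc1ccc2ccn(CCN3CCCN(C)CC3)c2c1` differs from compound 3 in one place: methyl in place of vinyl on an aromatic carbon. Going by the values given here, no measured step exchanges vinyl for methyl directly. The two large steps just named are the ones that bear on it: they show that, on that aromatic carbon, vinyl gave far more inhibition than hydroxy or carbamoyl. Methyl, like vinyl, carries no hydrogen-bond donors or acceptors, so the change from compound 3 is smaller in kind than those two steps. A drop is therefore expected, but a more modest one, estimated as a number 19 percentage points lower from compound 3 to compound 4 (beyond the scatter). Compound 4 is expected to give 60%, in the range 35% to 85%.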

Compound 4, a percentage reported as inhibition, at one concentration (the size of the read-out at that concentration, not a potency): 62%
Beside the measured number, compound 4's estimate is 2 percentage points below it; the range from low to high includes it.
By their numbers in this assay, from the lowest: compounds 1 and 2 (each within the scatter of the next); then compound 4; then compound 3.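

Vinyl is not the only group on this aromatic carbon that gives a high number in this assay: methyl also stands well clear of hydroxy, with a number 34 percentage points higher from compound 1 to compound 4 (beyond the scatter), and of carbamoyl, with a number 29 percentage points higher from compound 2 to compound 4 (beyond the scatter). Vinyl and methyl are still not interchangeable, as the change from two carbons and a double bond to a single carbon gives a number 17 percentage points lower from compound 3 to compound 4 (beyond the scatter). Nothing measured here explains these steps.

The compounds shown leave open whether the difference between vinyl and methyl follows the extra carbon or the double bond, a question that ethyl, which has the length of vinyl without its double bond, could separate. On these data alone, how an amine or a nitrile would behave on this aromatic carbon also remains open.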